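Cyclohexyl on the amide of compound 3

The source may hold more compounds than are shown below. What is called first, only, known or untested is meant among the compounds shown, and "the series" means these compounds.

Compound 1 `N[C@H]1CC[C@H](Nc2c(C(=O)NCc3ccc(Cl)cc3Cl)nc(Br)c3cccnc23)CC1`: 6000 nM
Compound 2 `O=C(NCc1ccc(F)cc1)c1nc(Br)c2cccnc2c1NCCO`: > 20000 nM, a limit
Compound 3 `C[C@H](NC(=O)c1nc(Br)c2cccnc2c1N[C@H]1CC[C@H](N)CC1)c1ccc(F)cc1`: > 10000 nM, a limit

All three were tested in a functional assay on HCT-116 cells (Homo sapiens) for cytotoxicity, read by MTT assay, with a stated time of 72 h; a higher number here means a weaker inhibitor, a lower number a stronger inhibitor. Compound 3 stands only at a limit, > 10000 nM, and so does compound 2. Compound 4 `N[C@H]1CC[C@H](Nc2c(C(=O)NC3CCCCC3)nc(Br)c3cccnc23)CC1` carries cyclohexyl in place of 1-(4-fluorophenyl)ethyl on an amide-type nitrogen. For the measured compounds named here, the only measured change at this nitrogen is an at least 1.6-fold higher number from compound 1 to compound 3 (0.22 log units; that floor lies within the scatter). This floor does not show a step beyond the scatter, so no clear shift is expected in this assay. The expected change is a step that the limit leaves unreadable from compound 3 to compound 4. For compound 4 the estimated value is 12000 nM, with an expected range of 5000 nM to 30000 nM.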

Compound 4, half-maximal inhibitory concentration: > 10000 nM
Compound 4 gave a limit, no number; the forecaster's own chance of this, stated with the estimate: 50%; the middle value does not contradict the limit.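

Putting cyclohexyl in place of 2,4-dichlorobenzyl on the amide-type nitrogen gives an at least 1.6-fold higher number from compound 1 to compound 4 (0.22 log units; that floor lies within the scatter) in this assay and so shows no step beyond the scatter. Compound 4 adds a non-aromatic ring to the groups tested at this nitrogen, and its result is a limit, not a number. The step linking it to compound 3 cannot be read because both results are limits: the limit of > 10000 nM in this assay, at which 2 of the 4 values shown sit.

As far as these compounds go, how far compound 4 lies past its limit stays open. From the compounds shown here alone, whether a longer chain or a carboxylic acid on this nitrogen would give a measurable number also stays open.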